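The source may report more compounds than this note shows. Statements on the series, on what has been measured and on what is new or still open speak of the compounds shown alone.

Two sulfonamides have so far been measured in an assay on HEK293 cells for inhibition of 17-beta-hydroxysteroid dehydrogenase type 2 (Homo sapiens), read by scintillation counting, with a stated time of 10 min, in the presence of a further agent that is not named here; a higher number here means a weaker inhibitor, a lower number a stronger inhibitor. Compound 1 `CC(C)(C)c1ccc(S(=O)(=O)Nc2cc(Cl)c(Cl)cc2N)cc1` gives 4650 nM in this assay. Compound 2 `CC(C)(C)c1ccc(S(=O)(=O)Nc2ccccc2O)cc1` gives 1230 nM in this assay, the lower of the two numbers; the gap to compound 1 lies beyond the usual scatter of such measurements, so compound 2 counts as the stronger inhibitor of the pair. Compound 3 `Cc1ccc(O)c(NS(=O)(=O)c2ccc(C(C)(C)C)cc2)c1` has not yet been measured. It differs from compound 2 in one place: methyl in place of hydrogen on an aromatic carbon of the six-membered aromatic ring, meta to a large group and para to the hydroxy group. Going by the values given here, no pair among the measured compounds shows what such an exchange does in this assay, so nothing measured speaks for a direction. The expected step is small, a 1.2-fold lower number from compound 2 to compound 3 (0.09 log units; within the scatter), with no direction beyond the scatter favoured, since the added group is a single carbon without a ring. Compound 3 is therefore expected to give about 1000 nM in this assay, within a range from 400 nM to 3000 nM.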

Compound 3, half-maximal inhibitory concentration: 4090 nM
For compound 3 the middle estimate is 4.1-fold (0.61 log units) below the measured one, outside the stated range (above it).
By their numbers in this assay, from the lowest: compound 2; then compounds 3 and 1 (each within the scatter of the next).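

The exchange of hydrogen for methyl on this aromatic carbon, meta to a large group and para to the hydroxy group, gives in this assay a 3.3-fold higher number from compound 2 to compound 3 (0.52 log units; beyond the scatter), so the weaker inhibition lies beyond the scatter. Going by these compounds alone, this is the first single-place change that can be read, as compound 1 and compound 2 differ in more than one place, and it shows that this position is not indifferent to substitution: one added carbon without a ring is enough to shift the number upward. No measurement at hand accounts for the size or direction of this step.

Going by these compounds, it remains open whether this loss is particular to methyl or would also appear with another group at the same carbon, such as fluorine, a methoxy group, an ethyl group or a carboxylic acid. On these data alone, it also remains open whether a methyl group on one of the other carbons of this six-membered aromatic ring would shift the number in the same direction, or whether the effect belongs to this position alone.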